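Swapping the acid-bearing side chain of compound 1

The compounds below may be only part of what the source reports. "The series", "measured", "known", "first", "only" and "open" are said of these compounds alone.

Measured so far:
compound 1, `O=C(O)/C=C/c1ccc(Cn2cccn2)cc1OCCc1ccc2ccccc2c1`, gives 12 nM
compound 2, `O=C(O)/C=C/c1ccc(OCc2ccccc2)cc1OCCc1ccc2ccccc2c1`, gives 850 nM

Among the compounds with values here, in an assay on CHO cells for displacement of a labelled ligand from prostaglandin E2 receptor EP3 subtype (Mus musculus), read by scintillation counting (a higher number here means a weaker inhibitor, a lower number a stronger inhibitor), compound 1 stands with the lower of the two numbers, and the single measured step, a 71-fold higher number from compound 1 to compound 2 (1.85 log units; beyond the scatter), concerns a different position of the shared core. Compound 3, `O=C(O)COc1ccc(Cn2cccn2)cc1OCCc1ccc2ccccc2c1`, differs from compound 1 by carboxymethoxy in place of 2-carboxyethenyl on an aromatic carbon. Within the data shown here, no measured step touches this part of the molecule, so the expectation rests only on the unchanged remainder of compound 1. A modest weakening is expected, a 2.9-fold higher number from compound 1 to compound 3 (0.46 log units; beyond the scatter), with wide uncertainty. Compound 3 is therefore estimated at 35 nM, between 6 nM and 250 nM.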

Compound 3, inhibition constant: 260 nM
Compound 3: middle estimate off by 7.4-fold (0.87 log units), on the low side; measured number above the stated range.
By their numbers in this assay, from the lowest: compound 1; then compound 3; then compound 2.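

Carboxymethoxy in place of 2-carboxyethenyl is the first measured change at this position, and in this assay it gives a 22-fold higher number from compound 1 to compound 3 (1.34 log units; beyond the scatter), so this position is not indifferent to the choice of acid-bearing chain. The two groups hold the same number of heavy atoms, yet the entering one has an oxygen on the ring and one double bond fewer. Nothing measured here explains the step.

Whether the ring oxygen or the lost double bond accounts for it stays open. A saturated 2-carboxyethyl chain or a longer carboxylic acid chain at this position would be informative.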